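Three Pyrazolines Share One Antiproliferative Level; a Fourth Awaits

This account rests on a few compounds, and the source may have more. Where it says the series, first, only, none or still open, it means among the compounds named here.

Compound 1, `Cc1cc(O)c(C2=NN(c3ccc(S(N)(=O)=O)cc3)C(c3ccccc3O)C2)cc1Cl`, 14600 nM; compound 2, `Cc1cc(O)c(C2=NN(c3ccc(S(N)(=O)=O)cc3)C(/C=C/c3ccccc3)C2)cc1Cl`, 14700 nM; compound 3, `COc1ccc(C2CC(c3cc(Cl)c(C)cc3O)=NN2c2ccc(S(N)(=O)=O)cc2)cc1OC`, 13300 nM.

All three measured compounds were tested in a functional assay on T47D cells (Homo sapiens) for antiproliferative activity, with a stated time of 48 h; on this read-out higher numbers stand for weaker inhibition of growth and lower numbers for stronger inhibition of growth. Compound 2 gives the highest of the three numbers, but its nearest neighbour and its furthest neighbour both lie within the scatter of it: a 1.0-fold higher number from compound 1 to compound 2 (0.00 log units; within the scatter) and a 1.1-fold lower number from compound 2 to compound 3 (0.04 log units; within the scatter). The third step, a 1.1-fold lower number from compound 1 to compound 3 (0.04 log units; within the scatter), is likewise within the scatter. On these numbers, then, compound 2 stands level with compound 1 and compound 3, and no order among the three can be read.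

Compound 4, `COc1ccc(C2CC(c3cc(Cl)c(C)cc3O)=NN2c2ccc(S(N)(=O)=O)cc2)c(OC)c1OC`, has not yet been measured. It differs from compound 2 in one place: 2,3,4-trimethoxyphenyl in place of 2-phenylethenyl on a saturated ring carbon. For the measured compounds named here, the steps that bear on this change are the replacement of the group on the same saturated ring carbon by a 2-hydroxyphenyl or a 3,4-dimethoxyphenyl group, and none of them moved the number beyond the scatter. The 2,3,4-trimethoxyphenyl group of compound 4 resembles the 3,4-dimethoxyphenyl group of compound 3 more than it resembles the others, so no step beyond the scatter is expected in this assay in either direction.

For compound 4 the estimate in this assay is therefore 13500 nM, with a range from 7000 nM to 27000 nM. This estimate means an expected step of a 1.1-fold lower number from compound 2 to compound 4 (0.04 log units; within the scatter).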

Compound 4, concentration for total growth inhibition: 7060 nM
The estimate for compound 4 lay 1.9-fold (0.28 log units) above the measured number, and the stated range covers the measured number.
By their numbers in this assay, from the lowest: compounds 4, 3, 1 and 2 (each within the scatter of the next, the first and the last beyond it).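

In this assay, for the compounds shown here, the 2,3,4-trimethoxyphenyl group on the saturated ring carbon produced the first steps at this position to pass beyond the scatter, though both are modest (a 2.1-fold lower number from compound 2 to compound 4 (0.32 log units; beyond the scatter) and a 2.1-fold lower number from compound 1 to compound 4 (0.32 log units; beyond the scatter)), so this carbon is not as indifferent to its substituent as the three earlier compounds suggested. The single added methoxy, by contrast, stays within the scatter (a 1.9-fold lower number from compound 3 to compound 4 (0.28 log units; within the scatter)), which means the new group stands apart from 2-phenylethenyl and 2-hydroxyphenyl but cannot be told apart from 3,4-dimethoxyphenyl on these numbers. Nothing at hand explains why this replacement shifted the number.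

The compounds shown leave open whether the methoxy pattern matters at all, since a 3,4,5-trimethoxyphenyl or a 2,4-dimethoxyphenyl group on the same carbon would be needed to tell whether the number of methoxy groups or their placement goes with the shift. They also leave open whether a quite different substituent there, such as a 4-(dimethylamino)phenyl group, a 4-carboxyphenyl group or a plain alkyl chain, would move the number further in either direction.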